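The source may hold more compounds than are shown below. What is called first, only, known or untested is meant among the compounds shown, and "the series" means these compounds.

For the measured compounds named here, compound 2 `OCc1cccc(-c2nccnc2OC2CN(c3ccc4ccccc4n3)C2)c1` is the less soluble of the two compounds measured so far: in a physicochemical assay for solubility, in phosphate buffer, at pH 7.4 (a higher number here means a more soluble compound, a lower number a less soluble compound), compound 2 gives 29000 nM, whereas compound 1 `CN(C)C1CCN(c2nccnc2OC2CN(c3ccc4ccccc4n3)C2)CC1` gives 500000 nM. Going by the values given here, the single measured step, a 17-fold lower number from compound 1 to compound 2 (1.24 log units; beyond the scatter), shows how much the group on the shared core can move the number.

Compound 3 `c1ccc2ncc(-c3nccnc3OC3CN(c4ccc5ccccc5n4)C3)cc2c1` has not yet been measured. Its difference from compound 2 is quinolin-3-yl in place of 3-(hydroxymethyl)phenyl on an aromatic carbon. The step from compound 1 to compound 2 bears on this change only loosely, since there an aliphatic amine gave way to an aromatic group, and it was large. Here a donor-bearing aromatic group gives way to a larger fused aromatic group with no donor; the one step on record gives no direct precedent for that. The expectation is nevertheless a further fall in this assay, of moderate size, a 5.8-fold lower number from compound 2 to compound 3 (0.76 log units; beyond the scatter). Compound 3 is therefore estimated at 5000 nM in this assay, within a range of 1000 nM to 25000 nM.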

Compound 3, solubility: < 1000 nM
Compound 3 gave a limit, no number; the forecaster's own chance of this, stated with the estimate: 10%; middle value at least 5.0-fold (0.69 log units) from the limit.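

In this assay compound 3 gives < 1000 nM, which is a limit of the assay and not a number. Exchanging one aromatic group for another at this position, next to the ring nitrogen, gives an at least 29-fold lower number from compound 2 to compound 3 (1.46 log units; beyond the scatter), so the number can move by a large step even when no aliphatic amine group leaves, as one did in the earlier step. Quinolin-3-yl in place of 4-(dimethylamino)piperidin-1-yl gives an at least 500-fold lower number from compound 1 to compound 3 (2.69 log units; beyond the scatter), which widens the span at this one position across the three compounds and leaves its lower end undefined: the limit of < 1000 nM in this assay, at which 1 of the 3 values shown sits.

The change from compound 2 to compound 3 removes the hydroxymethyl group and brings in a second aromatic ring in a single step, and the compounds shown do not separate these two changes, nor do they show how far past the limit compound 3 lies. Also open, going by these compounds, is where a plain phenyl would stand at this position, or a quinolin-3-yl carrying a hydroxymethyl group or a dimethylamino group.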